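The compounds below may be only part of what the source reports. "The series", "measured", "known", "first", "only" and "open" are said of these compounds alone.

Compound 1 `CC(C)n1c(C(F)(F)F)nc2cc(Cl)c(Cl)cc21`: 70500 nM
Compound 2 `FC(F)(F)c1nc2cc(Cl)c(Cl)cc2n1Cc1ccccc1`: 8700 nM
Compound 3 `FC(F)(F)c1cccc(Cn2c(C(F)(F)F)nc3cc(Cl)c(Cl)cc32)c1`: 68000 nM

In a functional assay on MCF7 cells (Homo sapiens) for cytotoxicity, read by MTT assay, with a stated time of 48 h (a higher number here means a weaker inhibitor of growth, a lower number a stronger inhibitor of growth), compound 2 gives the lowest of the three numbers, 8700 nM. Compound 4 `O=[N+]([O-])c1ccccc1Cn1c(C(F)(F)F)nc2cc(Cl)c(Cl)cc21` differs from compound 2 by one change: nitro in place of hydrogen on an aromatic carbon. The closest guide is a 7.8-fold higher number from compound 2 to compound 3 (0.89 log units; beyond the scatter), where trifluoromethyl takes the place of hydrogen on an aromatic carbon. The other measured step, an 8.1-fold lower number from compound 1 to compound 2 (0.91 log units; beyond the scatter), concerns the group on the aromatic nitrogen and bears on this change less directly. Going by the values given here, no nitro compound has been measured, so the guide is uncertain, but a higher number of modest size is expected in this assay. The expected change is a 2.9-fold higher number from compound 2 to compound 4 (0.46 log units; beyond the scatter). Compound 4 is estimated at 25000 nM, within an expected range of 8000 nM to 75000 nM.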

Compound 4, concentration for 50% growth inhibition: 1500 nM
For compound 4 the middle estimate is 17-fold (1.22 log units) above the measured one; measured number outside the range, below it.
By their numbers in this assay, from the lowest: compound 4; then compound 2; then compounds 3 and 1 (each within the scatter of the next).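

In this assay, nitro on an aromatic carbon, ortho to a large group, gives a 5.8-fold lower number from compound 2 to compound 4 (0.76 log units; beyond the scatter), so a substituent on this ring of the benzyl group need not raise the number. Set against a 7.8-fold higher number from compound 2 to compound 3 (0.89 log units; beyond the scatter), this shows that the two single changes made to compound 2 push the number in opposite directions. Nothing measured here accounts for this difference. The compounds shown leave open whether the gain belongs to nitro itself or to its place on the ring. They also leave open how an amine or a carboxylic acid would read at that same place.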